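A few compounds are considered here, and "the series" means these few. Any claim that something is new, unique, unknown or untested is made for them only; others in the source may bear on it.

Measured so far in a functional assay on HepG2 cells (Homo sapiens) for inhibition, read by MTT assay, with a stated time of 72 h; a lower number here means a stronger inhibitor, a higher number a weaker inhibitor:
compound 1 `COc1cc(/C=C/C(=O)c2c(O)cc(O)cc2OC)cc(OC)c1` gives 17600 nM
compound 2 `COc1cc(O)cc(O)c1C(=O)/C=C/c1ccc([N+](=O)[O-])cc1` gives 41000 nM
compound 3 `COc1cc(OC)c(C(=O)/C=C/c2ccc(O)cc2)c(OC)c1` gives 37000 nM

Compound 3 stands at 37000 nM in this assay and lies within the usual scatter of compound 2 at 41000 nM (repeat measurements could not tell these two apart). Compound 1 reads 17600 nM and this lower number lies beyond the scatter from compound 3.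

The next compound is compound 4 `COc1cc(OC)c(C(=O)/C=C/c2ccc(N)cc2)c(OC)c1` which differs from compound 3 in a single group: amino in place of hydroxy on an aromatic carbon, para to a large group. The difference counts as amino in place of hydroxy on an aromatic carbon and can also be read as 4-hydroxyphenyl to 4-aminophenyl.

Among the measured compounds shown here, no pair of measured compounds shows this swap, and so there is no direct precedent. With compound 1 at 17600 nM and compound 2 at 41000 nM the measured values span a narrow band, which suggests a small change here, with a slight lean towards a lower number. The expected change is a 1.5-fold lower number from compound 3 to compound 4 (0.19 log units; within the scatter) and nothing beyond the scatter is expected. The estimate for compound 4 is 24000 nM (expected range 8000 nM to 60000 nM).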

Compound 4, half-maximal inhibitory concentration: 45200 nM
Beside the measured number, compound 4's estimate is 1.9-fold (0.27 log units) below it; low and high end bracket the measured number.
By their numbers in this assay, from the lowest: compound 1; then compounds 3, 2 and 4 (each within the scatter of the next).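

In this assay, among the compounds shown here, putting amino in place of hydroxy on an aromatic carbon, para to a large group, gives a 1.2-fold higher number from compound 3 to compound 4 (0.09 log units; within the scatter), the first direct reading of a change at this position. This step lies within the scatter, so repeat measurements could not tell the two compounds apart, and on this core the assay shows no difference between a hydroxy and an amino group at this place. The swap exchanges one oxygen for one nitrogen and keeps the count of one hydrogen-bond donor and one hydrogen-bond acceptor, but nothing available explains why the reading stays within the scatter.

This single swap cannot show whether the position tolerates change in general, and a carboxylic acid, an acetamide or a fluorine at the same place could read quite differently. Also open, on these data alone, is whether amino in place of hydroxy would behave the same way on the core of compound 1 or compound 2, since each of those differs from compound 3 in more than one place.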